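Two Measurements, One Reordered Side Chain, One Estimate

The source may report more compounds than this note shows. Statements on the series, on what has been measured and on what is new or still open speak of the compounds shown alone.

Compound 1, with the structure `COc1ccc(/C=C/C(=O)c2cc(-c3cc(OC)c(OC)c(OC)c3)n3nc(-c4ccccc4)cc3n2)cc1`, and compound 2, with the structure `COc1cc(-c2cc(C(=O)/C=C/c3ccc(C)cc3)nc3cc(-c4ccccc4)nn23)cc(OC)c1OC`, share a core and differ only in one substituent. In a functional assay on MDA-MB-231 cells (Homo sapiens) for antiproliferative activity, read by MTT assay, with a stated time of 24 h (a higher number here means a weaker inhibitor, a lower number a stronger inhibitor), compound 1 gives 16500 nM, and in this assay compound 2 gives 18600 nM. Within the data shown here, the single step between them, a 1.1-fold higher number from compound 1 to compound 2 (0.05 log units; within the scatter), comes from a methyl in place of a methoxy on an aromatic carbon. Compound 2 therefore holds the highest of the two numbers, yet its nearest neighbour, compound 1, sits within the scatter of it, so no real order can be read between them.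

Compound 3, with the structure `COc1cc(-c2cc(/C=C/C(=O)c3ccc(Cl)cc3)nc3cc(-c4ccccc4)nn23)cc(OC)c1OC`, is not yet measured. It differs from compound 2 by 2-((4-chlorophenyl)carbonyl)ethenyl in place of (2-(4-methylphenyl)ethenyl)carbonyl on an aromatic carbon. The two side chains match in size, but their arrangement differs, and a chlorine stands where a methyl stood. Among the measured compounds shown here, the only measured step, the one from compound 1 to compound 2, concerns a small change on that same aromatic ring and stayed within the scatter. For the measured compounds named here, no measured step covers the rearrangement itself, so the expectation rests on thin ground and carries a wide range. Compound 3 is estimated at 17000 nM, between 7000 nM and 42000 nM, which as a step from compound 2 to compound 3 means an expected 1.1-fold lower number from compound 2 to compound 3 (0.04 log units; within the scatter), not beyond the scatter.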

Compound 3, half-maximal inhibitory concentration: 32500 nM
Estimate against measurement, compound 3: 1.9-fold (0.28 log units) below, and the stated range covers the measured number.
By their numbers in this assay, from the lowest: compounds 1, 2 and 3 (each within the scatter of the next).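

The earlier step touched only a small group on the outer ring, whereas this one rearranges the side chain itself at the position next to the ring nitrogen, and it gives a 1.7-fold higher number from compound 2 to compound 3 (0.24 log units; within the scatter) in this assay. The entering 2-((4-chlorophenyl)carbonyl)ethenyl has the same count of heavy atoms as the (2-(4-methylphenyl)ethenyl)carbonyl it replaces, but its carbonyl sits at the far end of the chain, by the outer ring, and a chlorine stands where the methyl stood. Measured against the methoxy-bearing chain, the same replacement gives a 2.0-fold higher number from compound 1 to compound 3 (0.29 log units; within the scatter), so both steps show that this rearrangement, taken together with the new ring substituent, does not move the number past the ordinary spread of repeat measurements.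

On these data alone, the rearrangement and the chlorine arrive in a single step, so their separate contributions remain unknown, and it remains open whether an amine or a carboxylic acid on the outer ring, or a longer chain in place of the ethenyl link, would give a step beyond that spread. Nothing on hand explains why these numbers fall where they do.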